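The source may report more compounds than this note shows. Statements on the series, on what has been measured and on what is new or still open speak of the compounds shown alone.

Measured so far:
compound 1, `O=C(C1CC12CCC2)N1CCc2nc(C#Cc3ccccc3)sc2C1`, 3.9 nM;
compound 2, `O=C(C1CCCCC1)N1CCc2nc(C#Cc3ccccc3)sc2C1`, 167 nM.

Both numbers come from an assay on HEK293 cells for positive allosteric modulation of metabotropic glutamate receptor 5 (Homo sapiens), read by FLIPR, with a stated time of 1 h; a lower number here means that less compound is needed, a higher number that more compound is needed for the effect. Within the data shown here, compound 2 stands highest of the two numbers, and its nearest neighbour is compound 1; the single step between them, a 43-fold higher number from compound 1 to compound 2 (1.63 log units; beyond the scatter), is the only comparison available in this assay, and it concerns the exchange of one saturated ring for another on the carbonyl carbon.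

Compound 3, `N#Cc1cccc(C(=O)N2CCc3nc(C#Cc4ccccc4)sc3C2)c1`, is not yet measured. Its change from compound 2 is 3-cyanophenyl in place of cyclohexyl on a carbonyl carbon. Among the measured compounds shown here, no measured step involves an aromatic group at this position. The step from compound 1 to compound 2 bears on the question only in showing that this assay moves strongly when the group on the carbonyl carbon is changed; it does not show in which direction an aromatic group moves the number. The expectation is therefore wide.

Compound 3 is estimated at 80 nM in this assay, with an expected range of 15 nM to 400 nM. The expected step of a 2.1-fold lower number from compound 2 to compound 3 (0.32 log units; beyond the scatter) is set modestly toward a lower number, while a step of some size in either direction would not be surprising.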

Compound 3, half-maximal effective concentration: 71 nM
Beside the measured number, compound 3's estimate is 1.1-fold (0.05 log units) above it; measured number inside the range.
By their numbers in this assay, from the lowest: compound 1; then compound 3; then compound 2.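

In this assay, among these compounds, 3-cyanophenyl is the first aromatic group seen on this carbonyl carbon, and it does not cost ground against cyclohexyl: the change gives a 2.4-fold lower number from compound 2 to compound 3 (0.37 log units; beyond the scatter). So the position accepts a flat aromatic ring carrying a nitrile as well as a saturated ring of the same size, and the number still improves modestly. The gain is small beside the distance to the group with the three-membered and four-membered rings, which shows as an 18-fold higher number from compound 1 to compound 3 (1.26 log units; beyond the scatter), so compound 1 keeps the lowest number of the three, and neither replacement of its group comes close to it. No accompanying observation bears on why these steps have this size or direction.

As far as these compounds go, whether the modest gain of compound 3 belongs to the aromatic ring itself or to the nitrile stays open, and a plain phenyl, a pyridyl or a methoxyphenyl on the same carbonyl carbon would separate the two. Also open, from the compounds shown here alone, is how far a smaller saturated group such as cyclopropyl or cyclobutyl, or an open chain such as tert-butyl, would approach compound 1.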